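The compounds below may be only part of what the source reports. "The series", "measured", "known", "first", "only" and "open" are said of these compounds alone.

Three compounds share one core and differ only in the group on a saturated chain carbon bound to an aromatic carbon. In an assay on CHO cells for displacement of a labelled ligand from adenosine receptor A1 (Homo sapiens), read by scintillation counting, tested at 10 uM (on this read-out lower numbers stand for less inhibition and higher numbers for more inhibition at the one concentration tested (going by the name of the read-out)), compound 1 `Cc1csc(N)c1C(=O)c1ccc(Cl)cc1` gives 1%. Compound 2 `CC(C)Cc1csc(N)c1C(=O)c1ccc(Cl)cc1` gives 1% in this assay, and compound 3 `CC(C)(C)Cc1csc(N)c1C(=O)c1ccc(Cl)cc1` gives 1%. The steps tell the same story: no change at the digits printed from compound 1 to compound 2 (within the scatter), no change at the digits printed from compound 1 to compound 3 (within the scatter) and no change at the digits printed from compound 2 to compound 3 (within the scatter). Compound 3 therefore stands level with compound 1 and compound 2 in this assay, with nothing separating the three beyond the scatter.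

Compound 4 `CC(C)(C)Cc1c(-c2cccnc2)sc(N)c1C(=O)c1ccc(Cl)cc1` takes a different route: pyridin-3-yl in place of hydrogen on an aromatic carbon. For the measured compounds named here, none of the measured steps touches an aromatic carbon, so no step bears directly on this change; the three steps that exist were all flat, and they enlarged a chain rather than placing a ring on the core. The expected step in this assay is a number 4 percentage points higher from compound 3 to compound 4 (within the scatter), small and uncertain. Compound 4 is estimated at 5% in this assay, with a range from 0% to 25%.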

Compound 4, a percentage reported as inhibition, at one concentration (the size of the read-out at that concentration, not a potency): 1%
Compound 4: the middle estimate sits 4 percentage points above what was measured, and the stated range covers the measured number.
By their numbers in this assay, from the lowest: compounds 1, 2, 3 and 4 (each within the scatter of the next).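

Earlier steps only enlarged a chain, while this one puts a whole ring on the core: in this assay, pyridin-3-yl on the aromatic carbon next to the ring sulfur gives no change at the digits printed from compound 3 to compound 4 (within the scatter) and so leaves the read-out where it was. A ring at this position, next to the ring atom that bears a neopentyl group, therefore makes no more difference at the one concentration tested than the chain changes did. Nothing on hand offers an explanation for this flat result.

From the compounds shown here alone, whether a carboxylic acid, an aminomethyl group or a phenyl ring on this same aromatic carbon would shift the number remains open. So does the question of whether replacing the amino group of the shared core would lift inhibition at all.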